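The source may hold more compounds than are shown below. What is called first, only, known or untested is meant among the compounds shown, and "the series" means these compounds.

Measured so far:
compound 1, `CCCCCNC(=O)Oc1ccc(Cl)cc1C(=O)Nc1ccc(Cl)cc1`: 43 h
compound 2, `CCCCCCNC(=O)Oc1ccc(Cl)cc1C(=O)Nc1ccc(Cl)cc1`: 43 h
compound 3, `CCCCCCCNC(=O)Oc1ccc(Cl)cc1C(=O)Nc1ccc(Cl)c(Cl)c1`: 43 h

The read-out is an ADME assay for metabolic stability, read by HPLC, at pH 7.4; on this read-out lower numbers stand for a shorter-lived compound and higher numbers for a longer-lived compound. Compound 1 gives 43 h. Compound 2 is the chain-extended partner of compound 1; the change is methyl in place of hydrogen on a saturated chain carbon, five bonds along the chain from an amide-type nitrogen, and the step is no change at the digits printed from compound 1 to compound 2 (within the scatter). Compound 3 sits on a different core, and the difference between the two cores is not broken down here; in this assay compound 3 gives 43 h, level with compound 1 and compound 2 within the scatter.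

Compound 4, `CCCCCCCCNC(=O)Oc1ccc(Cl)cc1C(=O)Nc1ccc(Cl)c(Cl)c1`, is not yet measured. It stands to compound 3 as compound 2 stands to compound 1, the change being (methyl in place of hydrogen on a saturated chain carbon, seven bonds along the chain from an amide-type nitrogen). The two places are not the same word for word: one is five bonds along the chain from an amide-type nitrogen, the other seven, so this is the same kind of change rather than the same change. Given the step of no change at the digits printed from compound 1 to compound 2 (within the scatter), the expected step is no change at the digits printed from compound 3 to compound 4 (within the scatter). Compound 4 is thus estimated at 43 h, with an expected range from 28 h to 65 h.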

Compound 4, half-life: 43 h
For compound 4 middle estimate and measured number coincide at the digits printed; the range from low to high includes it.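

In this assay, methyl in place of hydrogen on a saturated chain carbon, seven bonds along the chain from an amide-type nitrogen, gives this result: no change at the digits printed from compound 3 to compound 4 (within the scatter). Set beside the same kind of change on the core of compound 1, the step carries over to the core of compound 3 with no difference that can be told apart: the same change on two cores in this assay, no change at the digits printed (within the scatter) from compound 1 to compound 2 and no change at the digits printed (within the scatter) from compound 3 to compound 4, 1.0-fold (0.00 log units) apart, within the scatter of two such steps. This shows agreement between two flat steps only, at two different places on the chain and on two cores, so it does not show that the change would stay flat on a further core, or that a step of real size would carry over in the same way.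

As far as these compounds go, whether a longer chain, or a chain carrying an amine or a carboxylic acid, would stay level with these compounds in this assay remains open. Also open, from the compounds shown here alone, is whether a hydroxyl or an ether oxygen in the chain would leave the half-life equally unmoved on both cores.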